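A few compounds are considered here, and "the series" means these few. Any claim that something is new, unique, unknown or untested is made for them only; others in the source may bear on it.

Of the compounds shown here, three that share one core have been measured in a functional assay on Hs-578T cells (Homo sapiens) for inhibition, read by sulforhodamine B assay, with a stated time of 48 h; on this read-out higher numbers stand for weaker inhibition of growth and lower numbers for stronger inhibition of growth. Compound 1 `Nc1cc(N)c2nc(-c3ccccc3)c(Oc3ccc(Cl)c(Cl)c3)nc2c1` gives 10700 nM in this assay. Compound 3 `Nc1cc(N)c2nc(-c3ccccc3)c(NCc3ccc(Cl)c(Cl)c3)nc2c1` gives 5890 nM in this assay, the lowest of the two numbers shown, with compound 1 lying within the usual scatter of it. For compound 2 `CCOC(=O)[C@H](CCC(=O)O)NC(=O)c1ccc(CNc2nc3cc(N)cc(N)c3nc2-c2ccccc2)cc1` this assay reports only a limit, < 100000 nM, and that limit is the one described in the limit of < 100000 nM in this assay, at which 1 of the 3 values shown sits.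

Compound 4 `COc1ccc(CNc2nc3cc(N)cc(N)c3nc2-c2ccccc2)cc1OC` has not yet been measured in this assay. It differs from compound 3 in one place: 3,4-dimethoxyphenyl in place of 3,4-dichlorophenyl on a saturated chain carbon bound to a nitrogen on an aromatic ring. Within the data shown here, no pair of measured compounds shows this change, so the size of the step cannot be read from the data and rests on the resemblance of compound 4 to compound 3 alone. The step is expected to be a 1.5-fold higher number from compound 3 to compound 4 (0.18 log units; within the scatter), small and, if anything, toward weaker inhibition of growth. In this assay compound 4 is therefore estimated at 9000 nM, with a range from 2500 nM to 35000 nM.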

Compound 4, concentration for 50% growth inhibition: 33900 nM
Beside the measured number, compound 4's estimate is 3.8-fold (0.58 log units) below it; low and high end bracket the measured number.
By their numbers in this assay, from the lowest: compounds 3 and 1 (each within the scatter of the next); then compound 4.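

In this assay the group on a saturated chain carbon bound to a nitrogen on an aromatic ring proves sensitive to change: 3,4-dimethoxyphenyl in place of 3,4-dichlorophenyl gives a 5.8-fold higher number from compound 3 to compound 4 (0.76 log units; beyond the scatter) and this lies beyond the scatter. Among these compounds, the earlier compounds held no pair differing at this place alone, so this is the first sign that growth inhibition depends on the group carried here. The step points toward weaker inhibition of growth, yet it is a single exchange, and no measurement shown accounts for its size.

Going by these compounds, whether the loss follows from the methoxy groups entering or the chlorine atoms leaving stays open. An unsubstituted phenyl, a 4-chlorophenyl or a 3,4-difluorophenyl at this place would help to separate the two, and a pyridyl would test the aromatic ring of carbon itself.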